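Hydroxamate in place of dimethylamide on the cyclopropyl series

The source may hold more compounds than are shown below. What is called first, only, known or untested is meant among the compounds shown, and "the series" means these compounds.

For the measured compounds named here, compound 3 `Cc1nc(-c2ccc(C(F)(F)F)cc2)sc1CNc1ccc([C@H]2C[C@@H]2C(=O)N(C)C)cc1` gives 49% in a functional assay on CHO cells for agonist activity at Free fatty acid receptor 1 (Homo sapiens), read by a luciferase reporter (on this read-out lower numbers stand for smaller maximal responses and higher numbers for larger maximal responses), the second highest of the three numbers known here: compound 1 `Cc1nc(-c2ccc(C(F)(F)F)cc2)sc1CNc1ccc(CC(=O)O)cc1` gives 18% and compound 2 `Cc1nc(-c2ccc(C(F)(F)F)cc2)sc1CNc1ccc(CCC(N)=O)cc1` gives 88%. Compound 4 `Cc1nc(-c2ccc(C(F)(F)F)cc2)sc1CNc1ccc([C@H]2C[C@@H]2C(=O)NO)cc1` differs from compound 3 only as follows: hydroxyamino in place of dimethylamino on a carbonyl carbon. Going by the values given here, no measured step covers this change. The known steps, a number 70 percentage points higher from compound 1 to compound 2 (beyond the scatter), a number 31 percentage points higher from compound 1 to compound 3 (beyond the scatter) and a number 39 percentage points lower from compound 2 to compound 3 (beyond the scatter), show that the terminal group of this chain moves the maximal response by large amounts in either direction. Compound 4 is therefore expected to show a number 14 percentage points lower from compound 3 to compound 4 (beyond the scatter), with wide uncertainty. The estimated largest response of compound 4 in this assay is 35%, within a range from 15% to 60%.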

Compound 4, largest response reached (reported as percent of maximum), in percent of the reference or control that the assay uses: 78%
Beside the measured number, compound 4's estimate is 43 percentage points below it; the whole stated range lies below it.
By their numbers in this assay, from the lowest: compound 1; then compound 3; then compounds 4 and 2 (each within the scatter of the next).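

In this assay the change on the carbonyl carbon alone gives a number 29 percentage points higher from compound 3 to compound 4 (beyond the scatter) and so shows that the cyclopropyl chain does not by itself hold the response down. Set against the 2-carbamoylethyl chain, the step reads a number 10 percentage points lower from compound 2 to compound 4 (within the scatter) and leaves the two compounds indistinguishable, while against the carboxymethyl chain it reads a number 60 percentage points higher from compound 1 to compound 4 (beyond the scatter) and keeps the gap wide.

Still open, from the compounds shown here alone, is how a carboxylic acid or an unsubstituted amide on the same cyclopropyl carbonyl would read. Nothing given here accounts for the rise.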